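The source may hold more compounds than are shown below. What is called first, only, known or untested is meant among the compounds shown, and "the series" means these compounds.

Measured compounds:
compound 1 `CC(C)(C)c1ccc(-n2nnnc2SCC(=O)Nc2ccc(-c3ccc(CC(=O)O)cc3)cc2Cl)c(Cl)c1` with 0.383 h
compound 2 `CN(C(=O)CCC(=O)Nc1ccc(-c2ccc(OCC(=O)O)cc2)cc1Cl)c1ccc(C(C)(C)C)cc1Cl` with 0.9 h
compound 3 `CCN(C(=O)CCC(=O)Nc1ccc(-c2ccc(OCC(=O)O)cc2)cc1Cl)c1ccc(C(C)(C)C)cc1Cl` with 0.1 h

In an in vitro ADME assay on microsomes from liver (Homo sapiens) for metabolic stability (a lower number here means that the compound disappears faster, a higher number that the compound lasts longer), compound 3 gives 0.1 h, the lowest of the three numbers, with compound 1 nearest at 0.383 h and compound 2 furthest at 0.9 h. Compound 4 `C=CCN(C(=O)CCC(=O)Nc1ccc(-c2ccc(OCC(=O)O)cc2)cc1Cl)c1ccc(C(C)(C)C)cc1Cl` is not yet measured. It differs from compound 3 by vinyl in place of methyl on a saturated chain carbon bound to an amide-type nitrogen. For the measured compounds named here, one measured step bears on this place: the step of a 9.0-fold lower number from compound 2 to compound 3 (0.95 log units; beyond the scatter), where the chain on the amide-type nitrogen grew by one carbon and the number fell sharply. Compound 4 extends that same chain again, so a further fall, or at best no rise, is expected, though compound 3 already stands low and the assay may not resolve much more. For compound 4 the step of no change at the digits printed from compound 3 to compound 4 (within the scatter) is therefore expected, with a value estimated at 0.1 h and a range from 0.04 h to 0.25 h.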

Compound 4, half-life: 0.15 h
Beside the measured number, compound 4's estimate is 1.5-fold (0.18 log units) below it; the measured number falls inside the stated range.
By their numbers in this assay, from the lowest: compounds 3 and 4 (each within the scatter of the next); then compound 1; then compound 2.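

In this assay, vinyl in place of methyl on a saturated chain carbon bound to an amide-type nitrogen gives a 1.5-fold higher number from compound 3 to compound 4 (0.18 log units; within the scatter), so ethyl and allyl on that nitrogen cannot be told apart here. The sharp fall seen earlier with ethyl now has a second example with allyl, which gives a 6.0-fold lower number from compound 2 to compound 4 (0.78 log units; beyond the scatter), so it is not confined to a single chain. Nothing measured here accounts for either step.

As far as these compounds go, it remains open whether a longer chain, such as propyl or butyl, or a cyclopropyl ring on that nitrogen would give a number like those of compound 3 and compound 4. From the compounds shown here alone, it is equally open how a chain ending in a hydroxyl group or an amine, or a plain hydrogen on that nitrogen, would read in this assay.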